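A few compounds are considered here, and "the series" means these few. Any claim that something is new, unique, unknown or untested is made for them only; others in the source may bear on it.

Compound 1 `O=C(Nc1ccc(Cl)c(-c2nnc3c(Cl)cccn23)c1)c1ccccn1` in a functional assay on MDA-MB-468 cells (Homo sapiens) for antiproliferative activity, read by MTT assay, with a stated time of 72 h (on this read-out lower numbers stand for stronger inhibition and higher numbers for weaker inhibition), gives > 100000 nM, a limit of the assay and not a number.
Compound 2 `Cc1nc(C(=O)Nc2ccc(Cl)c(-c3nnc4c(Cl)cccn34)c2)cs1` in this assay gives > 100000 nM, likewise a limit.
Compound 3 `O=C(Nc1ccc(Cl)c(-c2nnc3c(Cl)cccn23)c1)c1ccc(Cl)cc1` in this assay gives > 100000 nM, also a limit.

The three steps joining them, a step that the two limits leave unreadable from compound 1 to compound 2, a step that the two limits leave unreadable from compound 1 to compound 3 and a step that the two limits leave unreadable from compound 2 to compound 3, have no readable size because of the limit of > 100000 nM in this assay, at which 3 of the 3 values shown sit. Compound 3 therefore stands only at that limit. Compound 4 `Cc1cc(Cl)ccc1C(=O)Nc1ccc(Cl)c(-c2nnc3c(Cl)cccn23)c1` differs from compound 3 by methyl in place of hydrogen on an aromatic carbon. Among the compounds with values here, no measured step bears on a methyl in place of hydrogen, so no direction can be drawn from them, and a limit is again the likeliest outcome. Compound 4 is expected at an estimated 150000 nM, with a range from 30000 nM to 500000 nM. The step this estimate means is a step that the limit leaves unreadable from compound 3 to compound 4, expected to lie within the scatter.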

Compound 4, half-maximal inhibitory concentration: 34300 nM
Estimate against measurement, compound 4: 4.4-fold (0.64 log units) above, and the stated range covers the measured number.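

In this assay, within the data shown here, a methyl on an aromatic carbon ortho to a large group gives the first readable change: an at least 2.9-fold lower number from compound 3 to compound 4 (0.46 log units; beyond the scatter). Against the other two groups on the carbonyl carbon, 4-chloro-2-methylphenyl gives an at least 2.9-fold lower number from compound 2 to compound 4 (0.46 log units; beyond the scatter) and an at least 2.9-fold lower number from compound 1 to compound 4 (0.46 log units; beyond the scatter). The steps among compound 1, compound 2 and compound 3 still cannot be read, and compound 4 alone stands off the limit: the limit of > 100000 nM in this assay, at which 3 of the 4 values shown sit.

Going by these compounds, whether an ethyl, a methoxy or a chloro on that same carbon would act as the methyl does remains open. So does the effect of a methyl elsewhere on this ring.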